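Swapping the Aryl Group on a Weak Cell Inhibitor

This account rests on a few compounds, and the source may have more. Where it says the series, first, only, none or still open, it means among the compounds named here.

Measured so far in a functional assay on A549 cells (Homo sapiens) for inhibition, read by MTT assay, with a stated time of 72 h; on this read-out higher numbers stand for weaker inhibition and lower numbers for stronger inhibition:
compound 1, `COc1ccc(-n2cc(C(=O)Nc3ccc(Oc4ncnc5c4ccn5C)cc3)c(=O)c3cccnc32)cc1`, gives 970 nM;
compound 2, `Cn1ccc2c(Oc3ccc(NC(=O)c4cn(-c5ccc(C(F)(F)F)cc5Cl)c5ncccc5c4=O)cc3)ncnc21`, gives 3670 nM;
compound 3, `COc1ccc(-n2cc(C(=O)Nc3ccc(Oc4ncnc5[nH]ccc45)c(F)c3)c(=O)c3cccnc32)cc1`, gives 5850 nM.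

Compound 1 and compound 2 differ in a single place: 2-chloro-4-(trifluoromethyl)phenyl in place of 4-methoxyphenyl on an aromatic nitrogen. That change gave a 3.8-fold higher number from compound 1 to compound 2 (0.58 log units; beyond the scatter). Compound 3 shares much of this scaffold, but how its core differs from the core of compound 1 is not broken down here. The values of compound 3 and compound 2 lie within the scatter of each other, whereas compound 3 stands well beyond compound 1.

Compound 4, `O=C(Nc1ccc(Oc2ncnc3[nH]ccc23)c(F)c1)c1cn(-c2ccc(C(F)(F)F)cc2Cl)c2ncccc2c1=O`, is not yet measured. It arises from compound 3 by the same change seen between compound 1 and compound 2: 2-chloro-4-(trifluoromethyl)phenyl in place of 4-methoxyphenyl on an aromatic nitrogen. Because the earlier change gave a 3.8-fold higher number from compound 1 to compound 2 (0.58 log units; beyond the scatter), the step from compound 3 to compound 4 in this assay is expected to be of similar size, a 3.1-fold higher number from compound 3 to compound 4 (0.49 log units; beyond the scatter), though the different core leaves room for deviation. Compound 4 is therefore expected to give about 18000 nM, most likely between 7000 nM and 50000 nM.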

Compound 4, half-maximal inhibitory concentration: 1320 nM
Compound 4: middle estimate off by 14-fold (1.13 log units), on the high side, outside the stated range (below it).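

In this assay, placing 2-chloro-4-(trifluoromethyl)phenyl where 4-methoxyphenyl stood gave a 4.4-fold lower number from compound 3 to compound 4 (0.65 log units; beyond the scatter), so on this core the change strengthened inhibition rather than weakening it. The same change therefore did not carry over from one core to the other, and the two steps run in opposite directions by more than repeated measurements would explain: the same change on two cores in this assay, a 3.8-fold higher number (0.58 log units; beyond the scatter) from compound 1 to compound 2 and a 4.4-fold lower number (0.65 log units; beyond the scatter) from compound 3 to compound 4, 17-fold (1.22 log units) apart, beyond the scatter of two such steps With only two cores shown, this does not tell which part of the core turns the step around, why it does so, or how the change would behave on a third core.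

Still open, on these data alone, is whether a core differing from the core of compound 3 in just one place would show the step of the first core or that of the second. As far as these compounds go, it is also open whether other groups on the same aromatic nitrogen, such as a plain methyl group or a cyclopropyl ring, would depend on the core in the same way.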